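Methoxy to hydroxy: from compound 3 to compound 4

The source may report more compounds than this note shows. Statements on the series, on what has been measured and on what is new or still open speak of the compounds shown alone.

Measured so far:
compound 1, `COc1cc(C)cc(-c2nn(CC#N)cc2-c2ccc(-c3cccc(C(C)=O)c3)nc2)c1`: a limit only, > 100000 nM
compound 2, `Cc1cc(O)cc(-c2nn(CC#N)cc2-c2ccnc(-c3ccc(Oc4ccccc4)cc3)c2)c1`: 39100 nM
compound 3, `COc1cc(C)cc(-c2nn(CC#N)cc2-c2ccnc(-c3ccc(N(C)C)cc3)c2)c1`: a limit only, > 100000 nM

Compound 3 stands in a functional assay on T47D cells (Homo sapiens) for inhibition, read by sulforhodamine B assay, with a stated time of 48 h (on this read-out higher numbers stand for lower toxicity in this test and lower numbers for higher toxicity in this test), at a limit of the test, not at a number. It shares that position with compound 1, since both sit at the limit of > 100000 nM in this assay, at which 2 of the 3 values shown sit. Within the data shown here, compound 2 is the only member of the set with a numerical value, and in this assay compound 2 gives 39100 nM. Among the measured compounds shown here, no pair in the measured set differs in a single place, so no measured step exists and the gap between compound 2 and the two limits cannot be read as a step.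

Compound 4, `Cc1cc(O)cc(-c2nn(CC#N)cc2-c2ccnc(-c3ccc(N(C)C)cc3)c2)c1`, is the partner of compound 3: hydrogen in place of methyl on an oxygen on an aromatic ring. Nothing measured tracks this change on its own; compound 2 carries the hydroxy group but also a different substituent on its pyridine ring. The step from compound 3 to compound 4 in this assay is therefore expected to be small, with a modest shift towards lower numbers at most, as an at least 1.2-fold lower number from compound 3 to compound 4 (0.09 log units; that floor lies within the scatter). Compound 4 is estimated at 80000 nM, within 25000 nM to 300000 nM, with a fair chance that only a limit is reported.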

Compound 4, concentration lethal to 50% of the cells: > 100000 nM
Compound 4: only a limit was reported (the forecaster's own chance of this, stated with the estimate: 55%); middle value at least 1.2-fold (0.09 log units) away from the limit.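

In this assay compound 4 gives > 100000 nM, which is a limit of the test and not a number. Compound 3 also sits at a limit, so the step from methoxy to hydroxy cannot be read, and hydroxy on the 3-hydroxy-5-methylphenyl group does not by itself bring a value onto the scale, at least with dimethylamino on the other side of the core. With that hydroxy group held constant, the set now has its first readable step, in which dimethylamino in place of phenoxy on an aromatic carbon gives an at least 2.5-fold higher number from compound 2 to compound 4 (0.40 log units; beyond the scatter), so phenoxy and dimethylamino can be told apart here while methoxy and hydroxy cannot.

As far as these compounds go, the size of the methoxy to hydroxy change remains open, since any reading would need a partner pair with a number on both sides, such as the methoxy counterpart of compound 2. Also open is whether the value of compound 2 is particular to phenoxy or would also appear with a benzyloxy group or a carboxylic acid in that place, and the spread of the set so far stays narrow: the limit of > 100000 nM in this assay, at which 3 of the 4 values shown sit.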